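The compounds below may be only part of what the source reports. "The series", "measured", "known", "first", "only" and "open" are said of these compounds alone.

Measured so far in an ADME assay on Caco-2 cells (Homo sapiens) for permeability, read by LC-MS, in the apical to basolateral direction, with a stated time of 120 min, tested at 10 uM; on this read-out lower numbers stand for lower permeability and higher numbers for higher permeability:
- compound 1, `COC(=O)[C@H]1CSCc2ccccc2C(=O)OC[C@H](NC(=O)[C@@H]2CCCN2C(C)=O)CN1`: 5.6 10^-6 cm/s
- compound 2, `COC(=O)[C@@H]1CSCc2ccccc2C(=O)OC[C@H](NC(=O)[C@@H]2CCCN2C(C)=O)CN1`: 0.8 10^-6 cm/s
- compound 3, `COC(=O)[C@H]1CSCc2ccccc2C(=O)OC[C@@H](NC(=O)[C@@H]2CCCN2C(C)=O)CN1`: 2.9 10^-6 cm/s

Compound 3 stands second highest of the three numbers. Its nearest neighbour is compound 1, with a 1.9-fold lower number from compound 1 to compound 3 (0.29 log units; within the scatter) separating them, a gap within the scatter; its furthest is compound 2, with a 3.6-fold higher number from compound 2 to compound 3 (0.56 log units; beyond the scatter) between them, a gap beyond the scatter.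

Compound 4, `COC(=O)[C@@H]1CSCc2ccccc2C(=O)OC[C@@H](NC(=O)[C@@H]2CCCN2C(C)=O)CN1`, is not yet measured. It differs from compound 3 as follows: the two compounds have the same atoms and bonds and differ only in configuration as drawn: 1 of 3 stereo elements differ; a stereocentre at a saturated ring carbon is drawn S in compound 3 and R in compound 4. This is the same stereocentre that separates compound 1 from compound 2, where the step was a 7.0-fold lower number from compound 1 to compound 2 (0.85 log units; beyond the scatter) (the fact that compounds 1 and 2 differ only in the configuration as drawn). The other single-centre step shown, a 1.9-fold lower number from compound 1 to compound 3 (0.29 log units; within the scatter) (the fact that compounds 1 and 3 differ only in the configuration as drawn), concerns a different centre and stayed within the scatter, so it does not speak to this change. The two-centre step a 3.6-fold higher number from compound 2 to compound 3 (0.56 log units; beyond the scatter) (the fact that compounds 2 and 3 differ only in the configuration as drawn) combines both changes and agrees in direction with the first.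

For compound 4 a lower number in this assay is therefore expected, with a step of about a 4.8-fold lower number from compound 3 to compound 4 (0.68 log units; beyond the scatter), on the same side of the scatter as the step from compound 1 to compound 2, though its size in the new background is uncertain. The estimate for compound 4 is 0.6 10^-6 cm/s, with a range from 0.25 10^-6 cm/s to 1.5 10^-6 cm/s.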

Compound 4, apparent permeability: 3.5 10^-6 cm/s
Compound 4: the middle estimate sits 5.8-fold (0.77 log units) below what was measured; the measured number lies above the stated range.
By their numbers in this assay, from the lowest: compound 2; then compounds 3, 4 and 1 (each within the scatter of the next).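

Notes on the series: in this assay, the stereocentre at the saturated ring carbon has no fixed effect, since the change that gave a large step in one background (a 7.0-fold lower number from compound 1 to compound 2 (0.85 log units; beyond the scatter)) stays within the scatter in the other (a 1.2-fold higher number from compound 3 to compound 4 (0.08 log units; within the scatter)). The second ring stereocentre now shows the same dependence on background, with a step beyond the scatter (a 4.4-fold higher number from compound 2 to compound 4 (0.64 log units; beyond the scatter)) where the earlier step at that centre lay within it (a 1.9-fold lower number from compound 1 to compound 3 (0.29 log units; within the scatter)). Changing both centres together also stays within the scatter (a 1.6-fold lower number from compound 1 to compound 4 (0.20 log units; within the scatter)), so among these four stereoisomers the low number belongs only to the combination drawn in compound 2, and neither centre alone accounts for it.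

The third stereocentre is drawn the same way in all four compounds, so its contribution cannot be read, and the compounds shown give no explanation for why compound 2 stands apart. Going by these compounds, it also remains open whether this dependence on the pair of centres would persist in an analogue of the shared core carrying a carboxylic acid or an amine.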